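Swapping a Phenyl for a Cyclohexylmethyl Group

The compounds below may be only part of what the source reports. "The series", "measured", "known", "first", "only" and "open" are said of these compounds alone.

Measured compounds:
compound 1, `CCCC/C(=C\c1cc(Oc2ccccc2)ccc1OCc1ccc(C(F)(F)F)cc1)C(=O)O`: 2100 nM
compound 2, `CCCC/C(=C\c1cc(OCc2ccc(CCCC)cc2)ccc1OCc1ccc(C(F)(F)F)cc1)C(=O)O`: "not active" (no number reported), no number given

The measurements come from an assay on isolated protein for inhibition of Polyunsaturated fatty acid 5-lipoxygenase (Homo sapiens), read by HPLC, with a stated time of 15 min; on this read-out higher numbers stand for weaker inhibition and lower numbers for stronger inhibition. In this assay, among the measured compounds shown here, compound 1 gives 2100 nM, the only number reported, while compound 2 gives "not active" (no number reported) without a number. For the measured compounds named here, no step between two measured compounds is available, so no measured change can be compared with the one considered here.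

Compound 3, `CCCC/C(=C\c1cc(OCC2CCC(C(F)(F)F)CC2)ccc1OCc1ccc(C(F)(F)F)cc1)C(=O)O`, has not yet been measured. It differs from compound 1 by (4-(trifluoromethyl)cyclohexyl)methyl in place of phenyl on an oxygen on an aromatic ring. Since compound 2, which also carries a different group on that oxygen, showed no activity, a modest weakening in this assay is expected for the change from compound 1 to compound 3, though it might stay within the scatter. Compound 3 is expected to give 5000 nM, with a range from 1500 nM to 20000 nM. The expected step is a 2.4-fold higher number from compound 1 to compound 3 (0.38 log units; beyond the scatter).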

Compound 3, half-maximal inhibitory concentration: 1700 nM
Compound 3: the middle estimate sits 2.9-fold (0.47 log units) above what was measured; low and high end bracket the measured number.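

In this assay the change reads as a 1.2-fold lower number from compound 1 to compound 3 (0.09 log units; within the scatter), so the phenyl and the (4-(trifluoromethyl)cyclohexyl)methyl group cannot be told apart at this position. An aromatic ring directly on this oxygen is therefore not needed for a measurable number, and compound 3 shows that a non-aromatic ring reached through a short link can also give one, while compound 2, with its own group on the same oxygen, gave no number at all. Nothing given here explains why compound 3 gives a number and compound 2 does not.

Going by these compounds, it remains open how a plain cyclohexylmethyl group, without the trifluoromethyl, would read on this oxygen, which would show whether the trifluoromethyl contributes anything. Also open, on these data alone, is how a group carrying an amine, such as a piperidinylmethyl group, would read here.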